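Furan-2-yl in Place of Methylamino on the Shared Core

The source may report more compounds than this note shows. Statements on the series, on what has been measured and on what is new or still open speak of the compounds shown alone.

For the measured compounds named here, of the two numbers known, compound 1 `CNc1ncnc2[nH]cc(Sc3cccs3)c12` gives 14700 nM in a functional assay on CCRF-CEM cells (Homo sapiens), read by MTT assay, with a stated time of 3 days (a lower number here means a stronger inhibitor, a higher number a weaker inhibitor), while compound 2 `c1csc(Sc2c[nH]c3ncnc(-c4cccs4)c23)c1` gives 10600 nM; the step of a 1.4-fold lower number from compound 1 to compound 2 (0.14 log units; within the scatter) lies within the scatter, so the two stand together. Compound 3 `c1coc(-c2ncnc3[nH]cc(Sc4cccs4)c23)c1` differs from compound 1 by furan-2-yl in place of methylamino on an aromatic carbon. Going by the values given here, the only step that bears on this change is a 1.4-fold lower number from compound 1 to compound 2 (0.14 log units; within the scatter), where one five-membered aromatic ring with 1 hetero atom also replaced methylamino, so no movement beyond the scatter is expected. Compound 3 is therefore estimated at 11000 nM, within a range of 5000 nM to 25000 nM. The expected step is a 1.3-fold lower number from compound 1 to compound 3 (0.13 log units; within the scatter).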

Compound 3, half-maximal inhibitory concentration: 7730 nM
For compound 3 the middle estimate is 1.4-fold (0.15 log units) above the measured one; measured number inside the range.
By their numbers in this assay, from the lowest: compounds 3, 2 and 1 (each within the scatter of the next).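

In this assay the place held by methylamino in compound 1 also takes furan-2-yl, with a 1.9-fold lower number from compound 1 to compound 3 (0.28 log units; within the scatter) on the shared core, and furan-2-yl in place of thiophen-2-yl gives a 1.4-fold lower number from compound 2 to compound 3 (0.14 log units; within the scatter) as well. Both steps stay within the scatter, so this read-out does not separate methylamino and the two five-membered aromatic rings at this position. No measurement at hand offers a reason for this. The compounds shown leave open whether a different group here, such as a carboxylic acid or a longer chain, would move the number beyond the scatter.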